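The source may hold more compounds than are shown below. What is called first, only, known or untested is meant among the compounds shown, and "the series" means these compounds.

Measured in an ADME assay on BJ cells (Homo sapiens) for cytotoxicity, read by MTT assay, with a stated time of 72 h; on this read-out higher numbers stand for weaker inhibition and lower numbers for stronger inhibition:
compound 1 `Oc1cccc(CNc2ncnc3c2ncn3C2CCCCO2)c1`: > 100000 nM
compound 2 `COc1cccc(OC)c1CNc1ncnc2c1ncn2C1CCCCO1`: > 100000 nM
compound 3 `COc1ccc(CNc2ncnc3c2ncn3C2CCCCO2)cc1OC`: > 100000 nM

All three entries are limits of the assay, not numbers. Compound 1 stands at the limit of > 100000 nM in this assay, at which 3 of the 3 values shown sit.

Compound 4 `Oc1cccc(CNc2ncnc3c2ncn3C2CCCCO2)c1O` differs from compound 1 by one change: hydroxy in place of hydrogen on an aromatic carbon. This takes 3-hydroxyphenyl to 2,3-dihydroxyphenyl, with the new hydroxy ortho to a hydroxy group. Among the compounds with values here, no measured step sizes this change. In this assay, no step beyond the scatter is expected; if a number does appear, it should lie toward stronger inhibition. The estimated step is a number no higher from compound 1 to compound 4 (the limit leaves the size open). For compound 4 the expected value is 100000 nM, with an estimated range of 40000 nM to 200000 nM.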

Compound 4, half-maximal inhibitory concentration: 63300 nM
Estimate against measurement, compound 4: 1.6-fold (0.20 log units) above; the range from low to high includes it.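

Among the compounds shown, compound 4 alone gives a number rather than a limit in this assay. Hydroxy in place of hydrogen on this aromatic carbon gives an at least 1.5-fold lower number from compound 1 to compound 4 (0.19 log units; that floor lies within the scatter) and so offers the first sign in the series that this position can affect the read-out. The true size of the step remains unfixed, since compound 1 holds only a limit.

On these data alone, it remains open whether the second hydroxy is specifically required, or whether an amine or a carboxylic acid at this position would also give a number.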